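The source may report more compounds than this note shows. Statements on the series, on what has been measured and on what is new or still open speak of the compounds shown alone.

In an ADME assay on the whole organism (Rattus norvegicus, strain Wistar Han) for pharmacokinetics, at a dose of 0.05 mg/kg by the intravenous route (on this read-out higher numbers stand for fast clearance and lower numbers for slow clearance), compound 3 (`CC(C(=O)Nc1ccc(Cl)cc1)N1CCC2C(CCCN2C(=O)OC2CC2)C1`) gives 22 mL/min/kg, the lower of the two single numbers and beyond the scatter from compound 2 (`O=C(CN1CCC2C(CCCN2C(=O)c2cccc(Cl)c2)C1)Nc1ccc(F)cc1`), which gives 61 mL/min/kg. Compound 4 (`Cc1nccc(N2CCCC3CN(C(C)C(=O)Nc4ccc(Cl)cc4)CCC32)n1`) carries 2-methylpyrimidin-4-yl in place of cyclopropyloxycarbonyl on an amine nitrogen in a ring. Going by the values given here, no measured pair shows this change alone. Compound 1 (`O=C(Nc1ccc(F)cc1)C1(C2CCC3C(CCCN3c3ccnc(C(F)(F)F)n3)C2)CCC1`) also has a six-membered aromatic ring with 2 hetero atoms on an amine nitrogen in a ring, and its entries of 36 mL/min/kg; 30 mL/min/kg; 19 mL/min/kg; 16 mL/min/kg (4 entries) fall on both sides of the number for compound 3. No step beyond the scatter is therefore expected in this assay. The expected change, a 1.3-fold higher number from compound 3 to compound 4 (0.10 log units; within the scatter), is an estimate that stays within the scatter. For compound 4 the estimated value is 28 mL/min/kg, with an expected range of 14 mL/min/kg to 55 mL/min/kg.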

Compound 4, clearance: 31 mL/min/kg
Compound 4: the middle estimate sits 1.1-fold (0.04 log units) below what was measured; measured number inside the range.
By their numbers in this assay, from the lowest: compounds 3, 4 and 2 (each within the scatter of the next, the first and the last beyond it).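

On this nitrogen, 2-methylpyrimidin-4-yl in place of cyclopropyloxycarbonyl gives, in this assay, a 1.4-fold higher number from compound 3 to compound 4 (0.15 log units; within the scatter), so the two groups cannot be told apart by clearance on this core. Going by these compounds alone, this is the first direct reading of an aromatic ring at this position against a non-aromatic group with the rest of the molecule held fixed. The step is no larger than the spread of repeat entries for a single compound: the several entries of compound 1 in this assay, 36 mL/min/kg; 30 mL/min/kg; 19 mL/min/kg; 16 mL/min/kg (4 entries)

Still open, as far as these compounds go, is how an acetyl or a methanesulfonyl group on this nitrogen would behave. From the compounds shown here alone, whether the result carries over to the core of compound 1 also remains open.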